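Sulfonamide aryl variation on a pyridyl acrylamide series

The source may hold more compounds than are shown below. What is called first, only, known or untested is meant among the compounds shown, and "the series" means these compounds.

Measured compounds:
- compound 1, `Cc1ccc(C)c(NS(=O)(=O)c2cccc(CCCCCCNC(=O)/C=C/c3cccnc3)c2)c1`: 11.6 nM
- compound 2, `O=C(/C=C/c1cccnc1)NCCCCCCc1cccc(S(=O)(=O)Nc2ccc(Cl)cc2)c1`: 10.8 nM

In an assay on isolated protein for inhibition of Nicotinamide phosphoribosyltransferase (Homo sapiens), read by WST assay, with stated times of 60 min, 5 min and 30 min, in the presence of a further agent that is not named here (a lower number here means a stronger inhibitor, a higher number a weaker inhibitor), compound 2 sits next to compound 1, and the step of a 1.1-fold lower number from compound 1 to compound 2 (0.03 log units; within the scatter) does not separate the two; on the numbers shown compound 2 is not distinguished from compound 1.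

Compound 3, `O=C(/C=C/c1cccnc1)NCCCCCCc1cccc(S(=O)(=O)Nc2ccc(F)c(Cl)c2)c1`, is not yet measured. Against compound 2 the change is 3-chloro-4-fluorophenyl in place of 4-chlorophenyl on a sulfonamide nitrogen.

Among the compounds with values here, the only measured step that touches the same place is a 1.1-fold lower number from compound 1 to compound 2 (0.03 log units; within the scatter), a swap of one aryl group on the sulfonamide nitrogen for another, and it stayed within the scatter. Nothing else among the two measured compounds bears on the aryl at this position. On that basis no step beyond the scatter is expected in this assay for compound 3, in either direction.

Compound 3 is therefore estimated at 11 nM, range 5 nM to 25 nM, an expected step of a 1.0-fold higher number from compound 2 to compound 3 (0.01 log units; within the scatter).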

Compound 3, half-maximal inhibitory concentration: 9.7 nM
Beside the measured number, compound 3's estimate is 1.1-fold (0.05 log units) above it, and the stated range covers the measured number.
By their numbers in this assay, from the lowest: compounds 3, 2 and 1 (each within the scatter of the next).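

In this assay, 3-chloro-4-fluorophenyl on the sulfonamide nitrogen, with fluorine and chlorine on the ring and one more heavy atom than 4-chlorophenyl, leaves the number within the scatter (a 1.1-fold lower number from compound 2 to compound 3 (0.05 log units; within the scatter)). Against 2,5-dimethylphenyl the same group also stays within the scatter (a 1.2-fold lower number from compound 1 to compound 3 (0.08 log units; within the scatter)), so none of the three aryl groups shown at this position is separated from the others, and the earlier single step now extends to a ring bearing two different halogens. No supporting data bear on why these three aryl groups read alike.

Going by these compounds, all three aryl groups carry only halogen or methyl substituents, so the reading for an aryl bearing an amine or a carboxylic acid remains open. Also open, on these data alone, is whether a cyclohexyl group in place of the aryl on the sulfonamide nitrogen would give a step beyond the scatter.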